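Swapping the amide's pyridyl for difluorophenyl: cytotoxicity outlook

The source may report more compounds than this note shows. Statements on the series, on what has been measured and on what is new or still open speak of the compounds shown alone.

Three analogues of one shared core have been tested in an ADME assay on LLC-MK2 cells (Macaca mulatta) for cytotoxicity, read by spectrophotometry and crystal violet staining, with a stated time of 4 days; on this read-out higher numbers stand for lower toxicity in this test and lower numbers for higher toxicity in this test. Compound 1 `CC(C)n1ncc2c(C(=O)Nc3ccccn3)cc(-c3ccsc3)nc21` gives 25000 nM, compound 3 `CC(C)n1ncc2c(C(=O)Nc3cccnc3)cc(-c3ccsc3)nc21` gives 37000 nM, and the step of a 1.5-fold higher number from compound 1 to compound 3 (0.17 log units; within the scatter) shows that moving the ring nitrogen changes little. Compound 2 `CC(C)n1ncc2c(C(=O)Nc3ccncc3)cc(-c3cccs3)nc21` gives 6300 nM, the lowest of the three numbers, beyond the scatter from both others. Compound 4 `CC(C)n1ncc2c(C(=O)Nc3ccc(F)c(F)c3)cc(-c3cccs3)nc21` is the unmeasured analogue of compound 2 with 3,4-difluorophenyl in place of pyridin-4-yl on an amide-type nitrogen. Within the data shown here, no measured pair covers this kind of exchange; the only related step, the pyridyl isomer change, lay within the scatter. The step from compound 2 to compound 4 is therefore expected to be modest, a 1.6-fold higher number from compound 2 to compound 4 (0.20 log units; within the scatter). Compound 4 is estimated at 10000 nM, within a range of 3500 nM to 30000 nM in this assay .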

Compound 4, half-maximal cytotoxic concentration: > 200000 nM
Compound 4: a limit, no number (the forecaster's own chance of this, stated with the estimate: 10%); middle value at least 20-fold (1.30 log units) from the limit.
By their numbers in this assay, from the lowest: compound 2; then compounds 1 and 3 (each within the scatter of the next). At a limit, above all of these: compound 4.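

In this assay, the group on the amide-type nitrogen proves able to shift the read-out strongly, with 3,4-difluorophenyl in place of pyridin-4-yl giving an at least 31-fold higher number from compound 2 to compound 4 (1.50 log units; beyond the scatter). Among these compounds, the earlier pyridyl change, by contrast, gave a 1.5-fold higher number from compound 1 to compound 3 (0.17 log units; within the scatter), so only this exchange shows how much this position can matter. The value of compound 4 is a limit of the assay and not a number: the limit of > 200000 nM in this assay, at which 1 of the 4 values shown sits.

On these data alone, how a plain phenyl or a monofluorophenyl on this nitrogen would read remains open. The step therefore cannot yet be divided between losing the pyridine nitrogen and gaining the two fluorines.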